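The source may report more compounds than this note shows. Statements on the series, on what has been measured and on what is new or still open speak of the compounds shown alone.

Measured in an ADME assay on HeLa cells (Homo sapiens) for cytotoxicity, read by crystal violet staining, with a stated time of 72 h; a higher number here means that more compound is tolerated, a lower number that less compound is tolerated:

- compound 1 `CCOC(=O)c1cc(CCCOc2ccc(-c3noc(C(F)(F)F)n3)cc2C)on1`: 35100 nM
- compound 2 `CCOC(=O)c1cc(CCCOc2ccc(-c3noc(C(F)(F)F)n3)cc2C(F)(F)F)on1`: 28400 nM

Among the compounds with values here, only two compounds have numbers so far, and compound 2, at 28400 nM, stands level with compound 1 within the scatter. The next compound to be tested is compound 3 `CCOC(=O)c1cc(CCCOc2ccc(-c3noc(C(F)(F)F)n3)cc2NC(C)=O)on1`, which carries acetamido in place of trifluoromethyl on an aromatic carbon. Within the data shown here, one measured step bears on this change: a 1.2-fold lower number from compound 1 to compound 2 (0.09 log units; within the scatter), which stays within the scatter and concerns the same aromatic carbon, where trifluoromethyl took the place of methyl. Among the measured compounds shown here, that step is weak guidance, since no measured compound carries acetamido and the two pairs of groups are not alike. Nothing in the numbers points in either direction, so no shift beyond the scatter in this assay is expected, though the uncertainty is wide. The expected step is a 1.1-fold higher number from compound 2 to compound 3 (0.05 log units; within the scatter), which would fall within the scatter. For compound 3 the estimated value is 32000 nM, with an expected range from 13000 nM to 75000 nM.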

Compound 3, half-maximal cytotoxic concentration: > 100000 nM
Compound 3: only a limit was reported (the forecaster's own chance of this, stated with the estimate: 15%); at least 3.1-fold (0.49 log units) between middle value and limit.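

In this assay compound 3 gives > 100000 nM, which is a limit of the assay and not a number. Methyl and trifluoromethyl on this aromatic carbon, ortho to a large group and meta to a 5-(trifluoromethyl)-1,2,4-oxadiazol-3-yl group, had stayed level with a 1.2-fold lower number from compound 1 to compound 2 (0.09 log units; within the scatter), whereas acetamido moves the number beyond the scatter, with an at least 3.5-fold higher number from compound 2 to compound 3 (0.54 log units; beyond the scatter) and with an at least 2.8-fold higher number from compound 1 to compound 3 (0.45 log units; beyond the scatter). The position is therefore not indifferent to what it carries in this assay, and the change from trifluoromethyl to acetamido keeps the same count of heavy atoms while bringing in a hydrogen-bond donor and a hydrogen-bond acceptor, which trifluoromethyl does not have.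

The true size of both steps stays open because the result for compound 3 is bounded on one side only: the limit of > 100000 nM in this assay, at which 1 of the 3 values shown sits. The compounds shown also do not tell whether the amide hydrogen, the carbonyl or the acetamido group as a whole goes with this shift, or whether an amine or a methoxy group on the same carbon would behave in the same way.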